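Swapping the pyridyl sulfonyl group in a rat inhibition series

The compounds below may be only part of what the source reports. "The series", "measured", "known", "first", "only" and "open" are said of these compounds alone.

Of the compounds shown here, two have been measured so far. Compound 1 `CNCc1cn(S(=O)(=O)c2ccco2)c(-c2cccnc2F)c1F` gives 75% in a functional assay on the whole organism (strain Jcl:Sprague-Dawley) for inhibition, with Rattus norvegicus as the target, with stated times of 3 min and 3 h, at a dose of 1 mg/kg by the intravenous route; a lower number here means less inhibition, a higher number more inhibition at the dose given (going by the name of the read-out). Compound 2 `CNCc1cn(S(=O)(=O)c2ccc(F)cn2)c(-c2cccnc2F)c1F` gives 87% in the same test, and the step of a number 12 percentage points higher from compound 1 to compound 2 (beyond the scatter) shows a modest gain. Going by the values given here, on these two numbers compound 2 stands highest, with compound 1 as its only neighbour and clearly separated from it.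

Compound 3 `CNCc1cn(S(=O)(=O)c2cncc(C)c2)c(-c2cccnc2F)c1F` is not yet measured. It differs from compound 2 in one place: 5-methylpyridin-3-yl in place of 5-fluoropyridin-2-yl on a sulfonyl sulfur. Among the compounds with values here, the only measured step, from compound 1 to compound 2, also changes the group on the sulfonyl sulfur, but neither of its two groups is the one entering here, so it gives no direct guide. With a pyridyl group kept on the sulfonyl sulfur, compound 3 is expected to land close to compound 2, and the step of a number 7 percentage points lower from compound 2 to compound 3 (within the scatter) is estimated to stay within the scatter. Compound 3 is therefore estimated at 80%, in a range from 60% to 95%.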

Compound 3, a percentage reported as inhibition, in the whole organism at one dose (the size of the read-out at that dose, not a potency): 87%
For compound 3 the middle estimate is 7 percentage points below the measured one, and the stated range covers the measured number.
By their numbers in this assay, from the lowest: compound 1; then compounds 2 and 3 (each within the scatter of the next).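

In this assay, the sulfonyl sulfur takes a second kind of pyridyl group with no visible loss: 5-methylpyridin-3-yl in place of 5-fluoropyridin-2-yl gives no change at the digits printed from compound 2 to compound 3 (within the scatter), so a fluorine on this ring is not needed to reach this level of inhibition. Replacing furan-2-yl with the new group gives a number 12 percentage points higher from compound 1 to compound 3 (beyond the scatter), matching the step of a number 12 percentage points higher from compound 1 to compound 2 (beyond the scatter), so both pyridyl compounds stand clear of the furan compound, although this rests on only these three compounds. Nothing available explains why the two pyridyl groups read alike.

Still open, going by these compounds, is whether a pyridine ring carrying an amine or a carboxylic acid, or a plain phenyl ring, would hold this level on the sulfonyl sulfur. A reading at one dose also cannot separate compound 2 from compound 3 in potency.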